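A few compounds are considered here, and "the series" means these few. Any claim that something is new, unique, unknown or untested is made for them only; others in the source may bear on it.

Measured so far:
- compound 1 `CCCCCCCN1CCC(C(=O)Nc2cc(Cl)c(N)cc2OC)CC1`: in a functional assay on the whole organism for antagonist activity, with Mus musculus as the target (on this read-out higher numbers stand for an effect only at larger amounts of compound and lower numbers for an effect already at smaller amounts), compound 1 reaches only the assay limit, > 10 mg/kg.
- compound 2 `COc1cc(N)c(Cl)cc1NC(=O)C1CCN(Cc2ccc(Cl)cc2)CC1`: compound 2 gives 1.2 mg/kg.
- compound 3 `COc1cc(N)c(Cl)cc1NC(=O)C1CCN(Cc2ccc(F)cc2)CC1`: compound 3 gives 0.6 mg/kg.

Compound 2 holds the higher of the two numbers; compound 3 is its nearest neighbour with a 2.0-fold lower number from compound 2 to compound 3 (0.30 log units; within the scatter), and the two cannot be told apart. Compound 1 stands only at a limit, (the limit of > 10 mg/kg in this assay, at which 1 of the 3 values shown sits). Relative to compound 1 the measured steps are an at least 8.3-fold lower number from compound 1 to compound 2 (0.92 log units; beyond the scatter) and an at least 16-fold lower number from compound 1 to compound 3 (1.22 log units; beyond the scatter).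

Compound 4 `COc1cc(N)c(Cl)cc1NC(=O)C1CCN(CC2CCCC2)CC1` differs from compound 2 by cyclopentyl in place of 4-chlorophenyl on a saturated chain carbon bound to an amine nitrogen in a ring. The step that bears on this change is the one in which hexyl gave way to 4-chlorophenyl, an at least 8.3-fold lower number from compound 1 to compound 2 (0.92 log units; beyond the scatter). Compound 4 keeps a ring on that saturated chain carbon, but a non-aromatic one, so it stands between compound 1 and compound 2 in kind. The chloro-to-fluoro exchange, a 2.0-fold lower number from compound 2 to compound 3 (0.30 log units; within the scatter), is within the scatter and does not inform this step. A modest rise in number is therefore expected, with a real chance of only a limit. Compound 4 is estimated at 3.5 mg/kg, range 1.2 mg/kg to 10 mg/kg. The expected step is a 2.9-fold higher number from compound 2 to compound 4 (0.46 log units; beyond the scatter).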

Compound 4, dose for half-maximal effect: > 10 mg/kg
Compound 4: no number, only a limit; the forecaster's own chance of this, stated with the estimate: 30%; middle value at least 2.8-fold (0.45 log units) from the limit.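

At this position, a saturated chain carbon bound to an amine nitrogen in a ring, keeping a ring is not enough: cyclopentyl gives an at least 8.3-fold higher number from compound 2 to compound 4 (0.92 log units; beyond the scatter) and an at least 16-fold higher number from compound 3 to compound 4 (1.22 log units; beyond the scatter). Among the compounds shown, numbers below the limit appear only with 4-chlorophenyl and 4-fluorophenyl, so here an aromatic ring goes with an effect at smaller amounts, while hexyl and cyclopentyl do not. Compound 4 is a limit, as is compound 1, so the step between them cannot be read: the limit of > 10 mg/kg in this assay, at which 2 of the 4 values shown sit.

Open, on these data alone, is whether a plain phenyl, without chloro or fluoro, would match compound 2 and compound 3. Also open, as far as these compounds go, is whether a pyridine ring or a cyclohexyl group on the same carbon would fall with the aromatic pair or with compound 4.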